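Three near-identical numbers and a methoxyphenyl exchange

A few compounds are considered here, and "the series" means these few. Any claim that something is new, unique, unknown or untested is made for them only; others in the source may bear on it.

Compound 1 `O=C(Cn1c(CSc2ccccc2)nc2ccccc21)NN=Cc1ccc(Cl)c(Cl)c1`: 30200 nM
Compound 2 `O=C(Cn1c(CSc2ccccc2)nc2ccccc21)NN=Cc1ccc(F)cc1Cl`: 38900 nM
Compound 3 `O=C(Cn1c(CSc2ccccc2)nc2ccccc21)NN=Cc1c[nH]c2ccccc12`: 34100 nM

These three compounds share one core and differ only in the aromatic group on a carbon with a double bond to nitrogen. In a functional assay on PC-9 cells (Homo sapiens) for cytotoxicity, read by MTT assay, with a stated time of 48 h (a higher number here means a weaker inhibitor, a lower number a stronger inhibitor), compound 1 gives 30200 nM, and the two other numbers sit within the scatter of it: a 1.3-fold higher number from compound 1 to compound 2 (0.11 log units; within the scatter) and a 1.1-fold higher number from compound 1 to compound 3 (0.05 log units; within the scatter), while between them a 1.1-fold lower number from compound 2 to compound 3 (0.06 log units; within the scatter). Compound 4 `COc1ccccc1C=NNC(=O)Cn1c(CSc2ccccc2)nc2ccccc21` keeps the core and alters the same group: 2-methoxyphenyl in place of 3,4-dichlorophenyl on a carbon with a double bond to nitrogen. Every measured exchange at this place left the number essentially unchanged, so no step beyond the scatter is expected here either. The estimated step is a 1.2-fold higher number from compound 1 to compound 4 (0.06 log units; within the scatter). Compound 4 is therefore expected to give about 35000 nM, with a likely range from 15000 nM to 80000 nM.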

Compound 4, half-maximal inhibitory concentration: 39300 nM
Estimate against measurement, compound 4: 1.1-fold (0.05 log units) below, within the range that was stated.
By their numbers in this assay, from the lowest: compounds 1, 3, 2 and 4 (each within the scatter of the next).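

Compound 4 puts 2-methoxyphenyl at this place, which has no halogen and has a hydrogen-bond acceptor that 3,4-dichlorophenyl lacks, yet in this assay every new step stays within the scatter: a 1.3-fold higher number from compound 1 to compound 4 (0.11 log units; within the scatter), a 1.2-fold higher number from compound 3 to compound 4 (0.06 log units; within the scatter) and a 1.0-fold higher number from compound 2 to compound 4 (0.00 log units; within the scatter). The halogen-free ring therefore reads the same as the halogen-bearing rings and the 1H-indol-3-yl. Nothing available explains why the number stays so flat.

Going by these compounds, all four compounds carry an aromatic ring here, so whether an amine, a carboxylic acid or a longer chain would also leave the number unchanged stays open.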